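Methyl in place of chloro: compound 3 to compound 4

A few compounds are considered here, and "the series" means these few. Any claim that something is new, unique, unknown or untested is made for them only; others in the source may bear on it.

Compound 1 `O=C(Sc1cccnc1C(=O)O)c1cccc(Cl)c1`: 4.7 h
Compound 2 `O=C(Sc1cccnc1C(=O)O)c1ccccc1Cl`: 27.2 h
Compound 3 `O=C(Sc1cccnc1C(=O)O)c1ccc(Cl)cc1`: 7.9 h

In a physicochemical assay for pharmacokinetics, at pH 6 (on this read-out lower numbers stand for a shorter-lived compound and higher numbers for a longer-lived compound), compound 3 gives 7.9 h and stands within the scatter of compound 1 at 4.7 h while compound 2 at 27.2 h lies higher, beyond the scatter. Compound 4 `Cc1ccc(C(=O)Sc2cccnc2C(=O)O)cc1` differs from compound 3 in one place, with methyl in place of chloro on an aromatic carbon, para to a large group (methyl in place of chloro on an aromatic carbon). For the measured compounds named here, no measured pair shows this exchange, so no change beyond the scatter is expected in this assay for it. The expected step (a 1.3-fold higher number from compound 3 to compound 4 (0.10 log units; within the scatter)) stays within the scatter. The estimate for compound 4 is 10 h with a range of 5 h to 20 h expected.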

Compound 4, half-life: 25.6 h
For compound 4 the middle estimate is 2.6-fold (0.41 log units) below the measured one; the measured number lies above the stated range.
By their numbers in this assay, from the lowest: compounds 1 and 3 (each within the scatter of the next); then compounds 4 and 2 (each within the scatter of the next).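

In this assay, for the compounds shown here, methyl in place of chloro on an aromatic carbon, para to a large group, gives a 3.2-fold higher number from compound 3 to compound 4 (0.51 log units; beyond the scatter) in the first single-place step of this set. The exchange therefore moves the half-life beyond the scatter, although each group counts one heavy atom and neither carries a hydrogen-bond donor or acceptor. Nothing available gives a reason for this step. Going by these compounds, it remains open whether the same exchange acts alike on compound 1 and compound 2, and whether a methoxy group or an amine in this place would follow methyl or chloro.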